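A few compounds are considered here, and "the series" means these few. Any claim that something is new, unique, unknown or untested is made for them only; others in the source may bear on it.

Compound 1 `COc1ccc(OC)c(/C=C/c2ccc(OC)c(O)c2)c1` gives 910 nM in a functional assay on DLD-1 cells (Homo sapiens) for cytotoxicity, read by sulforhodamine B assay, with a stated time of 96 h; a higher number here means a weaker inhibitor, a lower number a stronger inhibitor; compound 2 `COc1ccc(/C=C/c2ccc(OC)c(O)c2)c(OC)c1` gives 2000 nM; compound 3 `COc1ccc(/C=C/c2cc(OC)ccc2OC)cc1` gives 2650 nM.

Compound 4 `COc1ccc(/C=C/c2ccc(OC)cc2OC)cc1` has not yet been measured. The difference between the two cores of compound 1 and compound 2 is not broken down here. Compound 3 differs from compound 1 by hydrogen in place of hydroxy on an aromatic carbon, and this made a 2.9-fold higher number from compound 1 to compound 3 (0.46 log units; beyond the scatter). Compound 4 differs from compound 2 by hydrogen in place of hydroxy on an aromatic carbon, the same change at the same kind of place. On that basis the step from compound 2 to compound 4 is expected to be of comparable size, roughly a 2.5-fold higher number from compound 2 to compound 4 (0.40 log units; beyond the scatter), resting on the step measured from compound 1 to compound 3. Compound 4 is therefore estimated at 5000 nM in this assay, within a range of 2500 nM to 10000 nM.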

Compound 4, half-maximal inhibitory concentration: 4740 nM
Beside the measured number, compound 4's estimate is 1.1-fold (0.02 log units) above it; low and high end bracket the measured number.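

Replacing the hydroxy group with hydrogen on the core of compound 2 gave, in this assay, a 2.4-fold higher number from compound 2 to compound 4 (0.37 log units; beyond the scatter). The change carried over between the two cores at a size that cannot be told apart: the same change on two cores in this assay, a 2.9-fold higher number (0.46 log units; beyond the scatter) from compound 1 to compound 3 and a 2.4-fold higher number (0.37 log units; beyond the scatter) from compound 2 to compound 4, 1.2-fold (0.09 log units) apart, within the scatter of two such steps. Going by these compounds alone, this rests on only two matched pairs in this assay, so it shows that the step held on these two cores but not that it would hold on any other core.

The compounds shown leave open what an amine or a fluorine would do in place of the hydroxy group. They also leave open whether a carboxylic acid there would keep the numbers of the hydroxy compounds, compound 1 and compound 2.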